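This account rests on a few compounds, and the source may have more. Where it says the series, first, only, none or still open, it means among the compounds named here.

Working notes on the octylphenoxy ketone series in an assay on microsomes from brain for inhibition of Fatty-acid amide hydrolase 1 (Rattus norvegicus), read by fluorescence and HPLC, with a stated time of 60 min; on this read-out higher numbers stand for weaker inhibition and lower numbers for stronger inhibition. Compound 1 `CCCCCCCCc1ccc(OCC(=O)Cn2ncc3ccccc32)cc1` gives 2300 nM in this assay. Compound 2 `CCCCCCCCc1ccc(OCC(=O)Cn2cnc3cccnc32)cc1` gives 410 nM in this assay, and the change from compound 1 is a 5.6-fold lower number from compound 1 to compound 2 (0.75 log units; beyond the scatter). Compound 3 `CCCCCCCCc1ccc(OCC(=O)Cn2ccc3ncccc32)cc1` reaches only a limit of this assay, > 10000 nM. Among the measured compounds shown here, that limit is the one marked by the limit of > 10000 nM in this assay, at which 1 of the 3 values shown sits, and compound 3 is the sole member sitting on it. Relative to the two measured numbers compound 3 is the weakest of the three: an at least 4.3-fold higher number from compound 1 to compound 3 (0.63 log units; beyond the scatter) and an at least 24-fold higher number from compound 2 to compound 3 (1.38 log units; beyond the scatter).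

Compound 4 `CCCCCCCCc1ccc(OCC(=O)Cn2nnc3ncccc32)cc1` differs from compound 3 by a group of 9 heavy atoms (5 carbon, 4 nitrogen; one five-membered aromatic ring with 3 hetero atoms, one six-membered aromatic ring with 1 hetero atom) in place of a group of 9 heavy atoms (7 carbon, 2 nitrogen; one five-membered aromatic ring with 1 hetero atom, one six-membered aromatic ring with 1 hetero atom), on a saturated chain carbon bound to a carbonyl carbon. For the measured compounds named here, three measured steps bear on this change. Where the five-membered aromatic ring gained a hetero atom, the number fell (compound 1 to compound 2, modest); where it lost one, the number rose (compound 1 to compound 3, at least modest; compound 2 to compound 3, large). The change to compound 4 adds hetero atoms to the five-membered ring, so a lower number in this assay is expected, beyond the scatter, with its size uncertain since compound 3 shows only a limit. Compound 4 is therefore estimated at 1500 nM, within 300 nM to 10000 nM, an expected step of an at least 6.6-fold lower number from compound 3 to compound 4 (0.82 log units; beyond the scatter).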

Compound 4, half-maximal inhibitory concentration: 49 nM
Compound 4: middle estimate off by 31-fold (1.49 log units), on the high side; the whole stated range lies above it.
By their numbers in this assay, from the lowest: compound 4; then compound 2; then compound 1. At a limit, above all of these: compound 3.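

Compound 3 remains a limit of the assay and not a number, so its step to compound 4 can be read only as a bound: the limit of > 10000 nM in this assay, at which 1 of the 4 values shown sits. Even so, in this assay the group with three hetero atoms in the five-membered aromatic ring gives the lowest number of the series, with an at least 200-fold lower number from compound 3 to compound 4 (2.30 log units; beyond the scatter), an 8.4-fold lower number from compound 2 to compound 4 (0.92 log units; beyond the scatter) and a 47-fold lower number from compound 1 to compound 4 (1.67 log units; beyond the scatter), so this place on a saturated chain carbon bound to a carbonyl carbon tolerates far more ring nitrogen than the earlier compounds showed. Among compounds 3, 2 and 4, whose six-membered aromatic rings each hold one hetero atom, the number falls as the five-membered ring gains hetero atoms, but compound 1 goes against any reading by that count alone, since it matches compound 2 in the five-membered ring and still gives the higher number.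

These compounds do not separate the count of ring nitrogens from their arrangement, and a benzotriazole in this place would show whether the nitrogen of the six-membered ring in compound 4 contributes. As far as these compounds go, whether the low number of compound 4 survives with a hexyl chain in place of the octyl chain also remains open.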